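The source may report more compounds than this note shows. Statements on the series, on what has been measured and on what is new or still open speak of the compounds shown alone.

Values measured in a functional assay on HeLa cells (Homo sapiens) for antiproliferative activity, read by MTT assay, with a stated time of 48 h; on this read-out higher numbers stand for weaker inhibition and lower numbers for stronger inhibition:
- compound 1 `Cc1cc(Nc2nc(Nc3ccc(C(=O)NC4CC(C)(C)N([O])C(C)(C)C4)cc3)ncc2[N+](=O)[O-])no1`: 7360 nM
- compound 2 `Cc1cc(Nc2nc(Nc3ccc(C(=O)NC4CC(C)(C)N([O])C(C)(C)C4)cc3)ncc2[N+](=O)[O-])n[nH]1`: 29100 nM
- compound 3 `CCOC(=O)Cc1csc(Nc2nc(Nc3ccc(C(=O)NC4CC(C)(C)N([O])C(C)(C)C4)cc3)ncc2[N+](=O)[O-])n1`: 12000 nM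

Compound 2 has the highest number of the three, so it is the weakest inhibitor in this small set. The measured steps that touch it are a 2.4-fold lower number from compound 2 to compound 3 (0.38 log units; beyond the scatter) and a 4.0-fold higher number from compound 1 to compound 2 (0.60 log units; beyond the scatter). The remaining step, a 1.6-fold higher number from compound 1 to compound 3 (0.21 log units; within the scatter), does not involve it.

Compound 4 `Cc1cc(Nc2nc(Nc3ccc(C(=O)NC4CC(C)(C)N([O])C(C)(C)C4)cc3)ncc2F)n[nH]1` keeps the 5-methyl-1H-pyrazol-3-yl group of compound 2 and differs elsewhere: fluoro in place of nitro on an aromatic carbon. Among the compounds with values here, none of the measured steps covers this change, since all three exchange the group on nitrogen while the nitro stays. They show only how far single changes have moved this assay in this series, and they give no direction. No step beyond the scatter is therefore expected, though the uncertainty is wide. The estimate for compound 4 is 20000 nM, with an expected range of 6000 nM to 70000 nM. The expected change is a 1.5-fold lower number from compound 2 to compound 4 (0.16 log units; within the scatter).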

Compound 4, half-maximal inhibitory concentration: 11200 nM
Beside the measured number, compound 4's estimate is 1.8-fold (0.25 log units) above it, within the range that was stated.
By their numbers in this assay, from the lowest: compounds 1, 4 and 3 (each within the scatter of the next); then compound 2.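

In this assay, fluoro in place of nitro on the aromatic carbon ortho to the (5-methyl-1H-pyrazol-3-yl)amino group gives a 2.6-fold lower number from compound 2 to compound 4 (0.41 log units; beyond the scatter), so this position, which stays nitro in compound 1, compound 2 and compound 3, also moves the read-out beyond the scatter. The nitro group is thus not needed to reach this level of activity: a single fluorine takes the place of its three heavy atoms and the number falls, although the step is modest and rests on one pair. Nothing available accounts for why the number falls with this change.

From the compounds shown here alone, whether fluoro gives a similar step with the 5-methyl-1,2-oxazol-3-yl or 4-((ethoxycarbonyl)methyl)-1,3-thiazol-2-yl group on nitrogen remains open. Also open, going by these compounds, is how chloro, an amine or a nitrile would read at this place.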